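Pyridin-2-yl in Place of Pyridin-3-yl: Cytotoxicity Outlook

The source may hold more compounds than are shown below. What is called first, only, known or untested is meant among the compounds shown, and "the series" means these compounds.

Compound 1 `O=C(Nc1ncc(Cc2cccc3nsnc23)s1)C1CCCCC1`: > 40000 nM
Compound 2 `O=C(Nc1ncc(Cc2ccccc2)s1)C1CCCCC1`: > 40000 nM
Compound 3 `O=C(Nc1ncc(Cc2cccnc2)s1)C1CCCCC1`: "not determined" (no result reported)

In an ADME assay on P388D1 cells (Mus musculus) for cytotoxicity, read by fluorescence and resazurin assay, with a stated time of 72 h (on this read-out lower numbers stand for stronger inhibition and higher numbers for weaker inhibition), compound 1 gives > 40000 nM, which is a limit of the assay and not a number. Compound 2 gives > 40000 nM in this assay, again only a limit. For compound 3 the entry in this assay is "not determined" (no result reported). Compound 3 therefore has no single number to stand on; the two further values shown sit at the limit of > 40000 nM in this assay, at which 2 of the 3 values shown sit.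

Compound 4 `O=C(Nc1ncc(Cc2ccccn2)s1)C1CCCCC1` differs from compound 3 only by pyridin-2-yl in place of pyridin-3-yl on a saturated chain carbon bound to an aromatic carbon. Within the data shown here, no step between measured compounds exists, so nothing from the measured pairs indicates a change in this assay beyond the usual scatter in either direction. Among the measured compounds shown here, the only guide is that compound 1 and compound 2, whose groups on the same saturated chain carbon differ far more widely, both rest at the limit.

Compound 4 is expected in this assay to sit at 40000 nM, with a range from 20000 nM to 100000 nM, most probably reported only as a limit.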

Compound 4, half-maximal inhibitory concentration in the P388D1 assay: > 40000 nM
Compound 4 gave a limit, no number; the forecaster's own chance of this, stated with the estimate: 85%; the middle value sits exactly at the limit.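

Compound 4 rests at a limit in the P388D1 assay, as compound 2 does, so no step between compound 2 and compound 4 can be read: the limit of > 40000 nM in the P388D1 assay, at which 3 of the 4 values shown sit.

In a physicochemical assay for solubility, at pH 5 (a lower number here means a less soluble compound, a higher number a more soluble compound), compound 3 gives 590 ug/mL and compound 4 gives 480 ug/mL. That is a 1.2-fold lower number from compound 3 to compound 4 (0.09 log units; within the scatter).

Left open is what actual number compound 2 and compound 4 would give in the P388D1 assay, and how compound 3 compares with them there.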